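A Hydroxy Group Replaces Nitro on the Shared Core

The source may hold more compounds than are shown below. What is called first, only, known or untested is meant among the compounds shown, and "the series" means these compounds.

In a functional assay on MCF7 cells (Homo sapiens) for cytotoxicity, read by MTT assay, with a stated time of 48 h (on this read-out lower numbers stand for stronger inhibition and higher numbers for weaker inhibition), compound 1 `COc1ccc2c(c1)nc(/C=C/C(=O)/C=C/c1ccc(O)c(OC)c1)n2C` gives 3900 nM and compound 2 `COc1cc(/C=C/C(=O)/C=C/c2nc3cc([N+](=O)[O-])ccc3n2C)ccc1O` gives 3700 nM, so compound 2 stands level with compound 1 within the scatter. Within the data shown here, the one measured step, a 1.1-fold lower number from compound 1 to compound 2 (0.02 log units; within the scatter), is nitro in place of methoxy on an aromatic carbon, and it lies within the scatter. Compound 3 `COc1cc(/C=C/C(=O)/C=C/c2nc3cc(O)ccc3n2C)ccc1O` differs from compound 2 by hydroxy in place of nitro on an aromatic carbon. Among the measured compounds shown here, no measured compound carries a hydroxy group there, so the data offer only indirect guidance. Given the size of a 1.1-fold lower number from compound 1 to compound 2 (0.02 log units; within the scatter), no step beyond the scatter is expected in this assay, though the wide range allows for the untested group. The expected change is a 1.0-fold higher number from compound 2 to compound 3 (0.01 log units; within the scatter). For compound 3 the estimated value is 3800 nM, with an expected range from 1500 nM to 9500 nM.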

Compound 3, half-maximal inhibitory concentration: 2900 nM
Compound 3: middle estimate off by 1.3-fold (0.12 log units), on the high side; measured number inside the range.
By their numbers in this assay, from the lowest: compounds 3, 2 and 1 (each within the scatter of the next).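

In this assay this aromatic carbon now carries a third group, and hydroxy in place of nitro gives a 1.3-fold lower number from compound 2 to compound 3 (0.11 log units; within the scatter) while hydrogen in place of methyl on the oxygen gives a 1.3-fold lower number from compound 1 to compound 3 (0.13 log units; within the scatter) at the same place. Methoxy, nitro and hydroxy thus all stand level here, even though hydroxy is the only one of the three that brings a hydrogen-bond donor, so the position has not yet shown a step beyond the scatter. The data hold no evidence that could account for this flat result.

As far as these compounds go, whether an amine, a carboxylic acid or a longer chain such as butoxy at this carbon would move the number beyond the scatter remains open. Also open, from the compounds shown here alone, is whether the compounds stay level in other cell types.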